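This account rests on a few compounds, and the source may have more. Where it says the series, first, only, none or still open, it means among the compounds named here.

Measured compounds:
compound 1, `NC(=O)CC[C@H](NC(=O)CN(c1ncnc2c1ncn2C1CCCCO1)C1CC1)C(=O)OCc1ccccc1`, gives 10.7%
compound 2, `CSCC[C@H](NC(=O)CN(c1ncnc2c1ncn2C1CCCCO1)C1CC1)C(=O)OCc1ccccc1`, gives 17.5%
compound 3, `C[C@H](NC(=O)CN(c1ncnc2c1ncn2C1CCCCO1)C1CC1)C(=O)OCc1ccccc1`, gives 6.01%

All three values come from a functional assay on the whole organism (Tail, strain ICR) with Mus musculus as the target, in the tail flick test, with a stated time of 150 min, at a dose of 25 umol/kg by the oral route; on this read-out higher numbers stand for a stronger effect at the one dose given and lower numbers for a weaker effect. Among them compound 3 stands lowest, though its gap to compound 1 is small: a number 4.7 percentage points lower from compound 1 to compound 3 (within the scatter). Its gap to compound 2 is larger, a number 11.5 percentage points lower from compound 2 to compound 3 (beyond the scatter), and only that one reaches beyond the scatter. The step between compound 1 and compound 2, a number 6.8 percentage points higher from compound 1 to compound 2 (within the scatter), stays within the scatter.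

Compound 4, `CC(C)(C)OC(=O)NCCCC[C@H](NC(=O)CN(c1ncnc2c1ncn2C1CCCCO1)C1CC1)C(=O)OCc1ccccc1`, has not yet been measured. It differs from compound 3 in one place: 3-((tert-butoxycarbonyl)amino)propyl in place of hydrogen on a saturated chain carbon, two bonds along the chain from an amide-type nitrogen and a carbonyl carbon. The entering group has no ring and carries one hydrogen-bond donor and two hydrogen-bond acceptors.

The two measured steps that bear on this change both start from the same chain carbon of compound 3, where a hydrogen is replaced by a side chain. Replacing that hydrogen with carbamoylmethyl gave compound 1 and a step within the scatter; replacing it with (methylsulfanyl)methyl gave compound 2 and a modest step beyond the scatter. Neither side chain is as long as 3-((tert-butoxycarbonyl)amino)propyl, so the comparison is loose. From these two steps, compound 4 is expected to show a modest rise over compound 3, about a number 6 percentage points higher from compound 3 to compound 4 (within the scatter). The estimated value for compound 4 in this assay is 12%, with a likely range from 3% to 25%.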

Compound 4, a percentage reported as activity, at one dose (the size of the read-out at that dose, not a potency): 17.2%
Beside the measured number, compound 4's estimate is 5.2 percentage points below it; the range from low to high includes it.
By their numbers in this assay, from the lowest: compounds 3, 1, 4 and 2 (each within the scatter of the next, the first and the last beyond it).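

In this assay the saturated chain carbon, two bonds along the chain from an amide-type nitrogen and a carbonyl carbon, turns out to carry a much longer side chain than those seen before without losing the read-out: 3-((tert-butoxycarbonyl)amino)propyl, with its 11 heavy atoms, gives a number 11.2 percentage points higher from compound 3 to compound 4 (beyond the scatter) at this position. For the compounds shown here, this is the second side chain, after the one in compound 2, whose gain over the plain methyl of compound 3 lies beyond the scatter, while compound 1 goes against this pattern, its gap to compound 3 staying within the scatter. Measured against the shorter side chains, the picture is flat, with a number 0.3 percentage points lower from compound 2 to compound 4 (within the scatter) and a number 6.5 percentage points higher from compound 1 to compound 4 (within the scatter) showing that the added length brings no gain that can be told apart from the scatter.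

Still open, from the compounds shown here alone, is whether the read-out depends on the tert-butoxycarbonyl cap or on the chain that carries it, and what a free amine or a carboxylic acid at the end of a chain of this length would give. Nothing shown here explains any of these steps.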